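Swapping a Pyrrolidinylmethyl for an Acetyl Group

This account rests on a few compounds, and the source may have more. Where it says the series, first, only, none or still open, it means among the compounds named here.

Measured compounds:
compound 1 `CCOC(=O)c1cccc(-c2ccc(C)cc2)c1`: 63%
compound 2 `CCOC(=O)c1cccc(-c2ccc(CN3CCCC3)cc2)c1`: 33%

Both compounds were run in an assay on COS-7 cells for inhibition of patatin-like phospholipase domain-containing protein 2 (Mus musculus), tested at 200 uM; a lower number here means less inhibition, a higher number more inhibition at the concentration tested (going by the name of the read-out). Compound 1 gives 63%, while compound 2 gives 33%. Going by the values given here, compound 2 thus stands at the lower of the two numbers; its nearest neighbour is compound 1, and the single measured step between them, a number 30 percentage points lower from compound 1 to compound 2 (beyond the scatter), came with a pyrrolidin-1-yl in place of hydrogen on a saturated chain carbon bound to an aromatic carbon.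

Compound 3 `CCOC(=O)c1cccc(-c2ccc(C(C)=O)cc2)c1` is the next point. The change from compound 2 is acetyl in place of (pyrrolidin-1-yl)methyl on an aromatic carbon. Among the compounds with values here, no measured step covers this exact swap. Within the data shown here, the one step on record shows that attaching the pyrrolidine-bearing chain lowered the read-out; removing that chain could therefore pull the number back toward compound 1, but acetyl is a new group with no measured counterpart, so the direction is uncertain. A modest rise is expected, with wide room either way.

Compound 3 is expected to give about 48%, within roughly 25% to 70%. That estimate corresponds to an expected step of a number 15 percentage points higher from compound 2 to compound 3 (beyond the scatter).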

Compound 3, a percentage reported as inhibition, at one concentration (the size of the read-out at that concentration, not a potency): 36%
The estimate for compound 3 lay 12 percentage points above the measured number; the range from low to high includes it.
By their numbers in this assay, from the lowest: compounds 2 and 3 (each within the scatter of the next); then compound 1.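

In this assay, exchanging (pyrrolidin-1-yl)methyl for acetyl on this aromatic carbon, para to a large group, makes no clear difference: the result is a number 3 percentage points higher from compound 2 to compound 3 (within the scatter) and so two quite different groups, one carrying a five-membered non-aromatic ring with a nitrogen and one with no ring at all, cannot be told apart here. Acetyl in place of methyl at the same position gives a number 27 percentage points lower from compound 1 to compound 3 (beyond the scatter) and this shows that the fall seen earlier is not tied to the pyrrolidine ring or its nitrogen, since a group with neither ends up on the same side of compound 1. Nothing available explains why these two groups give such similar numbers.

Among these three compounds, methyl alone stands apart, and they cannot say whether it is special or whether plain hydrogen, an ethyl group or a methoxy group would behave the same way. Going by these compounds, it also remains open whether a carboxylic acid or a primary amine at this position would stay level with compound 2 and compound 3 or move away from them.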